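Swapping Chloro for Methoxy in a Growth Inhibitor

The source may report more compounds than this note shows. Statements on the series, on what has been measured and on what is new or still open speak of the compounds shown alone.

Compound 1 `O=C(CN1CCN(c2ccccc2F)CC1)Nc1ccc(-c2nc3ccccc3s2)cc1`: 200 nM
Compound 2 `Clc1cccc(-n2cc(CNc3ccc(-c4nc5ccccc5s4)cc3)nn2)c1`: 200 nM

Both values come from a functional assay on A549 cells (Homo sapiens) for inhibition; on this read-out higher numbers stand for weaker inhibition of growth and lower numbers for stronger inhibition of growth. Compound 2 stands level with compound 1, within the usual scatter of repeated measurements, although the two compounds differ in more than one place. Compound 3 `COc1cccc(-n2cc(CNc3ccc(-c4nc5ccccc5s4)cc3)nn2)c1` is compound 2 with a single change: methoxy in place of chloro on an aromatic carbon. This puts methoxy in place of chloro on an aromatic carbon, meta to a large group. For the measured compounds named here, no measured pair yet shows what a single change does in this assay, so the only anchor is compound 2 at 200 nM. The change is small, and a slight loss of growth inhibition seems the likelier direction, though this is only a cautious guess. The expected step is a 1.3-fold higher number from compound 2 to compound 3 (0.11 log units; within the scatter), which stays within the scatter. For compound 3 the estimated value is 260 nM, with an expected range of 90 nM to 750 nM.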

Compound 3, concentration for 50% growth inhibition: 200 nM
Compound 3: the middle estimate sits 1.3-fold (0.11 log units) above what was measured; the measured number falls inside the stated range.
By their numbers in this assay, from the lowest: compounds 1, 2 and 3 (each within the scatter of the next).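

In this assay, putting methoxy in place of chloro on an aromatic carbon, meta to a large group, brings no change at the digits printed from compound 2 to compound 3 (within the scatter). For the compounds shown here, compounds 1 and 2 differ in more than one place, so this is the first pair that isolates a single change; it shows that this position can take 3-methoxyphenyl in place of 3-chlorophenyl, with one more heavy atom and a hydrogen-bond acceptor, without a readable shift in growth inhibition. No supporting measurement here explains why the two groups read alike.

Two groups alone say little about how much variety this position accepts. An amine, a carboxylic acid or a longer chain in the same place could keep this level of growth inhibition or move it clearly in either direction.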